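Swapping methoxy for fluoro on the pendant phenyl ring

The compounds below may be only part of what the source reports. "The series", "measured", "known", "first", "only" and "open" are said of these compounds alone.

Measured compounds:
Compound 1, `c1ccc2c(-c3cn4ccnc4c(-c4ccc5ncn(C6CCCCC6)c5c4)n3)cccc2c1`: 7.84%
Compound 2, `Fc1ccc(-c2cn3ccnc3c(-c3ccc4ncn(C5CCCCC5)c4c3)n2)cc1`: 10.7%
Compound 3, `COc1ccccc1-c1cn2ccnc2c(-c2ccc3ncn(C4CCCCC4)c3c2)n1`: 8.04%

All three compounds share one core and differ only in the aryl group attached to it. In a functional assay on SF-268 cells (Homo sapiens) for inhibition, read by sulforhodamine B assay, with a stated time of 48 h, tested at 10 uM (on this read-out higher numbers stand for more inhibition at the one concentration tested (going by the name of the read-out) and lower numbers for less inhibition), compound 3 gives 8.04%, the second highest of the three numbers. Its nearest neighbour is compound 1, and the step of a number 0.2 percentage points higher from compound 1 to compound 3 (within the scatter) is within the scatter; the step of a number 2.7 percentage points lower from compound 2 to compound 3 (within the scatter) is within the scatter too, as is a number 2.9 percentage points higher from compound 1 to compound 2 (within the scatter). In short, none of the three aryl groups tried so far has moved the read-out beyond what repeated measurements would show on their own.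

Compound 4, `Fc1ccccc1-c1cn2ccnc2c(-c2ccc3ncn(C4CCCCC4)c3c2)n1`, has not yet been measured. Relative to compound 3 the change is fluoro in place of methoxy on an aromatic carbon. Within the data shown here, the steps that bear on this are the three aryl swaps just described, each of them within the scatter, so a further swap of one small substituent on the same ring is expected to leave the number essentially where it is, with no step beyond the scatter in either direction.

Compound 4 is therefore expected to give about 9%, in a range from 0% to 20%, which means an expected step of a number 1 percentage points higher from compound 3 to compound 4 (within the scatter).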

Compound 4, a percentage reported as inhibition, at one concentration (the size of the read-out at that concentration, not a potency): 6.04%
Estimate against measurement, compound 4: 3 percentage points above; the range from low to high includes it.
By their numbers in this assay, from the lowest: compounds 4, 1, 3 and 2 (each within the scatter of the next).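

In this assay the exchange of methoxy for fluoro, on an aromatic carbon ortho to a large group, reads as a number 2 percentage points lower from compound 3 to compound 4 (within the scatter), so this smaller substituent on the ring gives a number that cannot be told apart from that of the larger one. The other two comparisons add that the choice of aryl group still does not separate the compounds: 2-fluorophenyl in place of 4-fluorophenyl gives a number 4.7 percentage points lower from compound 2 to compound 4 (within the scatter), and 2-fluorophenyl in place of naphthalen-1-yl gives a number 1.8 percentage points lower from compound 1 to compound 4 (within the scatter), which means that all four compounds now sit within the usual scatter of one another and that swapping the fluoro group's location on the ring shows no clear effect. No separate measurement is available that could explain these numbers.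

The compounds shown leave open whether any group at this position can produce a step beyond the scatter, for example an amine or a carboxylic acid on the phenyl ring, or a longer chain such as butoxy in place of methoxy. With readings at only one concentration, they also leave open how potent any of these compounds is.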